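Series notes: cyano for methyl on the fused ring system

The source may report more compounds than this note shows. Statements on the series, on what has been measured and on what is new or still open speak of the compounds shown alone.

Going by the values given here, compound 3 `COc1cc(F)ccc1N1CCN(CCCNc2c(C(=O)N(C)C)cnc3c(C)cccc23)CC1` gives the highest number of the three measured so far in a functional assay for antagonist activity at Alpha-1A adrenergic receptor (Oryctolagus cuniculus) (a higher number here means weaker binding, a lower number tighter binding), at 7.94 nM. Compound 1 `CN(C)C(=O)c1cccnc1NCCCN1CCN(c2ccccc2OC(F)(F)F)CC1` gives 3.16 nM in this assay, and compound 2 `CN(C)C(=O)c1cccnc1NCCCN1CCN(c2ccccc2-c2ccccc2)CC1` gives 1.26 nM in this assay, so compound 3 stands nearest to compound 1 and furthest from compound 2, both gaps beyond the scatter. Among the compounds with values here, the only single-place step measured, a 2.5-fold lower number from compound 1 to compound 2 (0.40 log units; beyond the scatter), exchanges trifluoromethoxy for phenyl and does not touch the fused ring system that compound 3 carries.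

Compound 4 `COc1cc(F)ccc1N1CCN(CCCNc2c(C(=O)N(C)C)cnc3c(C#N)cccc23)CC1` differs from compound 3 by cyano in place of methyl on an aromatic carbon. Within the data shown here, no measured pair alters a substituent on that fused ring system, so nothing in the set bears directly on this change; the one known step is modest and sits elsewhere. The step is therefore expected to be a 1.0-fold lower number from compound 3 to compound 4 (0.00 log units; within the scatter), within the usual scatter. Compound 4 is estimated at 7.9 nM in this assay, with a range from 3.2 nM to 20 nM.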

Compound 4, dissociation constant: 1.26 nM
For compound 4 the middle estimate is 6.3-fold (0.80 log units) above the measured one; the measured number lies below the stated range.
By their numbers in this assay, from the lowest: compounds 2 and 4 (each within the scatter of the next); then compound 1; then compound 3.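

The aromatic carbon of the fused ring system is a position where a single substituent exchange moves the result in this assay: a 6.3-fold lower number from compound 3 to compound 4 (0.80 log units; beyond the scatter), a larger step than the only earlier one, which lay elsewhere in the molecule. Cyano brings 1 hydrogen-bond acceptor and 2 heavy atoms where methyl has 0 hydrogen-bond acceptors and 1 heavy atom, but this single pair cannot separate those differences from one another. No measurement at hand accounts for the step.

The compounds shown leave open whether a chlorine, a methoxy or a primary amide at this position would sit with cyano or with methyl. They also leave open whether the same exchange gives a similar step when the trifluoromethoxy or phenyl group of the other compounds is present.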